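A few compounds are considered here, and "the series" means these few. Any claim that something is new, unique, unknown or untested is made for them only; others in the source may bear on it.

Working notes on the series. Compound 1 `CCOc1ccc([C@@H]2CC(=O)c3cc(CC=C(C)C)c(OC)cc3O2)cc1` gives, in a functional assay on A549 cells (Homo sapiens) for inhibition, read by sulforhodamine B assay, with a stated time of 48 h, tested at 50 uM (on this read-out lower numbers stand for less inhibition of growth and higher numbers for more inhibition of growth at the one concentration tested), a value of 37%. Compound 2 `COc1ccc([C@@H]2C/C(=N/OCc3cn(-c4cccc(CO)c4)nn3)c3cc(CC=C(C)C)c(OC)cc3O2)cc1` gives in this assay a value of 43%, and compound 3 `COc1cc2c(cc1CCC(C)C)C(=O)C[C@@H](c1ccc(O)cc1)O2` gives 75% in the same this assay. Among these three numbers compound 2 stands second highest: its nearest neighbour is compound 1, whose number lies lower but within the scatter, so no order between compound 1 and compound 2 can be read; the furthest is compound 3, whose number lies higher by a gap beyond the scatter.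

Compound 4 `COc1ccc([C@@H]2C/C(=N/OCc3cn(-c4cccnc4Cl)nn3)c3cc(CC=C(C)C)c(OC)cc3O2)cc1` has not been measured. It differs from compound 2 in one place: 2-chloropyridin-3-yl in place of 3-(hydroxymethyl)phenyl on an aromatic nitrogen. Going by the values given here, no measured pair isolates this exchange, so nothing observed speaks for a direction. The working expectation is that the step of a number 2 percentage points higher from compound 2 to compound 4 (within the scatter) stays within the scatter, neither clearly up nor down. On that basis compound 4 is estimated at 45% in this assay, with a range from 25% to 65%.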

Compound 4, percent growth inhibition at one concentration: 58%
Estimate against measurement, compound 4: 13 percentage points below; measured number inside the range.
By their numbers in this assay, from the lowest: compounds 1 and 2 (each within the scatter of the next); then compound 4; then compound 3.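

Going by these compounds alone, the group on the aromatic nitrogen of the five-membered ring is not a silent position in this assay: 2-chloropyridin-3-yl in place of 3-(hydroxymethyl)phenyl gives a number 15 percentage points higher from compound 2 to compound 4 (beyond the scatter), the first step that isolates a single place. This one exchange alters several things together, namely the ring hetero atom, the chlorine and the hydroxymethyl group with its hydrogen-bond donor, so the pair alone cannot assign the step to any one of them. Nothing at hand links the step to a measured property of either group.

The compounds shown leave open whether the chlorine or the ring nitrogen of the entering group carries the step. Also open, from the compounds shown here alone, is what an unsubstituted phenyl, or a phenyl bearing an amine or a carboxylic acid, would give at this place.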